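The source may hold more compounds than are shown below. What is called first, only, known or untested is meant among the compounds shown, and "the series" means these compounds.

Working notes on the series.

Among the compounds with values here, compound 2 `COc1ccc(-c2cnc3nc(N)nc(N4CCN(C(=O)Nc5ccc(C#N)cc5)CC4)c3n2)cc1OC` gives 74 nM in a functional assay on cells (T-cell, Homo sapiens) for inhibition (on this read-out lower numbers stand for stronger inhibition and higher numbers for weaker inhibition), the lowest of the two numbers so far. Within the data shown here, compound 1 `COc1ccc(-c2cnc3nc(N)nc(N4CCN(c5ccc(C)cc5)CC4)c3n2)cc1OC` gives 300 nM in this assay; the step of a 4.1-fold lower number from compound 1 to compound 2 (0.61 log units; beyond the scatter) is the only measured step in the set and runs from a 4-methylphenyl on the ring nitrogen to the (4-cyanophenyl)carbamoyl of compound 2.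

Compound 3 `COc1ccc(-c2cnc3nc(N)nc(N4CCN(Cc5ccc(C(C)(C)C)cc5)CC4)c3n2)cc1OC` is not yet measured. Its change from compound 2 is 4-(tert-butyl)benzyl in place of (4-cyanophenyl)carbamoyl on an amine nitrogen in a ring. Among the measured compounds shown here, the entering 4-(tert-butyl)benzyl has no hydrogen-bond donor and no acceptor, and it resembles the 4-methylphenyl of compound 1 more than the carbamoyl of compound 2, so the one measured step argues for a return toward the number of compound 1 rather than a further fall. Compound 3 is therefore expected to give 250 nM in this assay, within 80 nM to 800 nM, as the estimated step of a 3.4-fold higher number from compound 2 to compound 3 (0.53 log units; beyond the scatter).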

Compound 3, half-maximal inhibitory concentration: 4300 nM
Estimate against measurement, compound 3: 17-fold (1.24 log units) below; measured number outside the range, above it.
By their numbers in this assay, from the lowest: compound 2; then compound 1; then compound 3.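

At this amine nitrogen in a ring, 4-(tert-butyl)benzyl in place of (4-cyanophenyl)carbamoyl costs far more in this assay than the earlier step gained: a 58-fold higher number from compound 2 to compound 3 (1.76 log units; beyond the scatter). The position also separates two groups that both lack the carbamoyl, with a 14-fold higher number from compound 1 to compound 3 (1.16 log units; beyond the scatter), so absence of the carbamoyl alone does not fix the number at this position. No accompanying measurement bears on the origin of these differences.

The compounds shown leave open whether the large rise follows the loss of the carbamoyl, the loss of the nitrile or the arrival of the tert-butyl, since these changes travel together in one step. A 4-cyanobenzyl or an unsubstituted benzyl on the same nitrogen would separate these contributions.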